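The compounds below may be only part of what the source reports. "The series", "measured", "known", "first", "only" and "open" are said of these compounds alone.

Measured compounds and their values in an ADME assay on liver (Homo sapiens) for metabolic stability, read by LC-MS, using microsomes and NADPH; a higher number here means that more of the compound is left, a lower number that less of the compound is left:

compound 1 `Cc1cc(CN(CC2CCCC2)[C@@H](CC(=O)O)c2ccc(Cl)cc2)ccc1OCCN1C(=O)CCC1=O` gives 78%
compound 2 `CCN(Cc1ccc(OCCn2c(=O)ccn(C)c2=O)c(C)c1)C(CC(=O)O)c1ccc(Cl)cc1` gives 46%
compound 3 `CCCN(Cc1ccc(OCCn2c(=O)ccn(C)c2=O)c(C)c1)C(CC(=O)O)c1ccc(Cl)cc1` gives 30%

Compound 1 stands highest of the three in this assay, and its steps to compound 2 and to compound 3 both lie beyond the scatter. Compound 2 and compound 3 share one core, compound 1 has another; the difference between the two cores is not broken down here. Within the shared core of compound 2 and compound 3, compound 3 differs from compound 2 by methyl in place of hydrogen on a saturated chain carbon, two bonds along the chain from an amine nitrogen, and the step that goes with it is a number 16 percentage points lower from compound 2 to compound 3 (beyond the scatter).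

Compound 4 `CCc1cc(CN(CC2CCCC2)[C@@H](CC(=O)O)c2ccc(Cl)cc2)ccc1OCCN1C(=O)CCC1=O` has not yet been measured. It differs from compound 1 by methyl in place of hydrogen on a saturated chain carbon bound to an aromatic carbon. This is the same kind of change as that from compound 2 to compound 3, a methyl entering on a saturated chain carbon, but the place differs: in compound 3 the carbon is two bonds along the chain from an amine nitrogen, in compound 4 it is bound to an aromatic carbon. Among the measured compounds shown here, only one measured pair shows this kind of change, so the expectation rests on that pair alone. The step from compound 1 to compound 4 in this assay is expected to be a number 16 percentage points lower from compound 1 to compound 4 (beyond the scatter), in the same direction and of similar size as the earlier one, because the step of a number 16 percentage points lower from compound 2 to compound 3 (beyond the scatter) was a modest decrease. Compound 4 is therefore estimated at 62%, with a range expected from 48% to 76%.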

Compound 4, percent of the compound remaining: 48%
Compound 4: middle estimate off by 14 percentage points, on the high side, within the range that was stated.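

In this assay, methyl in place of hydrogen on a saturated chain carbon bound to an aromatic carbon, which turns the methyl of compound 1 into the ethyl of compound 4, gives a number 30 percentage points lower from compound 1 to compound 4 (beyond the scatter). Set beside the earlier step on the other core, the change lowers the number on both cores, and the two sizes cannot be told apart: the same change on two cores in this assay, a number 16 percentage points lower (beyond the scatter) from compound 2 to compound 3 and a number 30 percentage points lower (beyond the scatter) from compound 1 to compound 4, 14 percentage points apart, within the scatter of two such steps This supports carrying the direction of the change from one core to the other in this series, but it rests on two pairs only, the change sits at a different place in each pair, and nothing here explains the loss or shows that the size would hold on a further core.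

The compounds shown leave open whether a longer chain such as propyl, or a chlorine atom or methoxy group in place of the methyl of compound 1, would follow the same direction in this assay. They also leave open whether the step on the core of compound 1 would look the same with a group other than cyclopentylmethyl on the amine nitrogen, for example a plain ethyl or propyl chain.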